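Replacing 2-fluorophenyl with (2-chlorophenyl)carbonyl on an amine nitrogen

The compounds below may be only part of what the source reports. "The series", "measured", "known", "first", "only" and "open" are said of these compounds alone.

Within the data shown here, in a functional assay on OVCAR-3 cells (Homo sapiens) for antiproliferative activity, read by MTT assay, with a stated time of 24 h (on this read-out lower numbers stand for stronger inhibition and higher numbers for weaker inhibition), compound 2 `O=C(NNc1ccccc1F)c1cccc(NS(=O)(=O)c2cnc(O)nc2O)c1` gives 17000 nM as the only actual number so far. Compound 1 `Cc1ccccc1NNC(=O)c1ccc(NS(=O)(=O)c2cnc(O)nc2O)cc1` returns > 20000 nM as a limit and not a number. Compound 3 `O=C(NNC(=O)c1ccccc1Cl)c1cccc(NS(=O)(=O)c2cnc(O)nc2O)c1` carries (2-chlorophenyl)carbonyl in place of 2-fluorophenyl on an amine nitrogen and remains unmeasured. Among the measured compounds shown here, no measured step in this assay bears on this change, so the expectation rests on compound 2 with 17000 nM alone. The expected step of a 1.3-fold higher number from compound 2 to compound 3 (0.11 log units; within the scatter) is small, a slight weakening that may stay within the scatter. Compound 3 is therefore expected to give an estimated 22000 nM (range 10000 nM to 50000 nM).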

Compound 3, half-maximal inhibitory concentration: 7300 nM
For compound 3 the middle estimate is 3.0-fold (0.48 log units) above the measured one; the whole stated range lies above it.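

Placing (2-chlorophenyl)carbonyl in place of 2-fluorophenyl on an amine nitrogen gives a 2.3-fold lower number from compound 2 to compound 3 (0.37 log units; beyond the scatter) in this assay. Among these compounds, this is the only readable step, and it shows that this position accepts the added carbonyl and responds to a change of group. Compound 1 remains a limit and not a number: the limit of > 20000 nM in this assay, at which 1 of the 3 values shown sits.

The carbonyl and the chlorine enter together, and the compounds shown leave open which of them carries the step. From the compounds shown here alone, how a carboxylic acid or a longer chain would read on this nitrogen also stays open.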